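Trifluoromethyl for Chloro on Two Related Cores

A few compounds are considered here, and "the series" means these few. Any claim that something is new, unique, unknown or untested is made for them only; others in the source may bear on it.

Compound 1 `O=C1C2CCCN2C(=O)N1CN1CCN(c2cccc(Cl)c2)CC1` and compound 3 `O=C1C2CCCCN2C(=O)N1CN1CCN(c2cccc(Cl)c2)CC1` both carry a chloro group on the aromatic ring but differ in their cores; the difference between the two cores is not broken down here. In an assay on isolated protein for binding affinity to Adrenergic receptor alpha-1 (Rattus norvegicus), read by radioligand binding (on this read-out higher numbers stand for weaker inhibition and lower numbers for stronger inhibition), compound 3 gives 135 nM, the lowest of the two numbers, and compound 1 gives 292 nM. Compound 2 `O=C1C2CCCN2C(=O)N1CN1CCN(c2cccc(C(F)(F)F)c2)CC1` differs from compound 1 by trifluoromethyl in place of chloro on an aromatic carbon. In this assay compound 2 gives only a limit of the assay, > 1000 nM. The resulting step, an at least 3.4-fold higher number from compound 1 to compound 2 (0.53 log units; beyond the scatter), is bounded by the limit of > 1000 nM in this assay, at which 1 of the 3 values shown sits, and may be larger than the figure shows. Compound 4 `O=C1C2CCCCN2C(=O)N1CN1CCN(c2cccc(C(F)(F)F)c2)CC1` has not yet been measured; it differs from compound 3 by the same change, (trifluoromethyl in place of chloro on an aromatic carbon), at the same place. With the change and its place the same, compound 4 is expected to show a 4.4-fold higher number from compound 3 to compound 4 (0.65 log units; beyond the scatter). That expectation rests on an at least 3.4-fold higher number from compound 1 to compound 2 (0.53 log units; beyond the scatter) applied to compound 3 at 135 nM. Compound 4 is estimated in this assay at 600 nM, between 250 nM and 1500 nM, with a fair chance that only a limit is reported.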

Compound 4, inhibition constant: > 1000 nM
Compound 4 ended at the assay's limit; the forecaster's own chance of this, stated with the estimate: 35%; middle value at least 1.6-fold (0.22 log units) away from the limit.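

In this assay compound 4 gives > 1000 nM, which is a limit of the assay and not a number. Trifluoromethyl in place of chloro on an aromatic carbon gives an at least 7.4-fold higher number from compound 3 to compound 4 (0.86 log units; beyond the scatter), so the change weakens binding on both cores shown, and its direction carries over from one core to the other: the same change on two cores in this assay, an at least 3.4-fold higher number (0.53 log units; beyond the scatter) from compound 1 to compound 2 and an at least 7.4-fold higher number (0.86 log units; beyond the scatter) from compound 3 to compound 4; the limit leaves it open whether they differ. What does not carry over is any size, since neither trifluoromethyl compound gives a number, and the data cannot say whether one core is more sensitive to this change than the other: the limit of > 1000 nM in this assay, at which 2 of the 4 values shown sit.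

The compounds shown hold only chloro and trifluoromethyl at this place, on two cores, so a pattern cannot be claimed beyond these four compounds. As far as these compounds go, what a methoxy group, a nitrile or an amine on the same aromatic carbon would do on either core stays open, as does the effect of a longer chain joining the two halves of the molecule.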